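This account rests on a few compounds, and the source may have more. Where it says the series, first, only, none or still open, it means among the compounds named here.

Measured so far:
compound 1 `O=C1c2c[n+]([O-])c3ccccc3c2C(=O)c2c1c1ccccc1n2Cc1cn(CC(O)CO)nn1` — 1110 nM in a functional assay on MCF7 cells (Homo sapiens) for cytotoxicity, read by MTT assay, with a stated time of 72 h; on this read-out lower numbers stand for stronger inhibition and higher numbers for weaker inhibition
compound 2 `CCCN1CCN(CCCCn2c3c(c4ccccc42)C(=O)c2c[n+]([O-])c4ccccc4c2C3=O)CC1` — 1280 nM

Compound 1 stands lowest of the two numbers in this assay, but compound 2 lies within the scatter of it, so the two cannot be ordered. Compound 3 `O=C1c2c[n+]([O-])c3ccccc3c2C(=O)c2c1c1ccccc1n2Cc1cn([C@@H]2O[C@H](CO)[C@@H](O)[C@H](O)[C@H]2O)nn1` differs from compound 1 in one place: 3,4,5-trihydroxy-6-(hydroxymethyl)oxan-2-yl in place of 2,3-dihydroxypropyl on an aromatic nitrogen. Among the measured compounds shown here, the only step measured, a 1.2-fold higher number from compound 1 to compound 2 (0.06 log units; within the scatter), changed a far larger part of the same side chain and stayed within the scatter, so the shared core appears to carry most of the effect. A step within the scatter, or slightly weaker, is therefore expected here, a 1.4-fold higher number from compound 1 to compound 3 (0.13 log units; within the scatter). For compound 3 the estimate is 1500 nM, within 600 nM to 4000 nM.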

Compound 3, half-maximal inhibitory concentration: 590 nM
Compound 3: the middle estimate sits 2.5-fold (0.41 log units) above what was measured, and the stated range ends above it.
By their numbers in this assay, from the lowest: compounds 3, 1 and 2 (each within the scatter of the next, the first and the last beyond it).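

On the aromatic nitrogen of the five-membered ring, 3,4,5-trihydroxy-6-(hydroxymethyl)oxan-2-yl, with 11 heavy atoms and a six-membered non-aromatic ring, can take the place of 2,3-dihydroxypropyl, with 5 heavy atoms and no ring, giving a 1.9-fold lower number from compound 1 to compound 3 (0.27 log units; within the scatter). This position therefore tolerates a much larger group with more hydrogen-bond donors, with no change beyond the scatter. No evidence here explains this result. Still open, going by these compounds, is whether a carboxylic acid or a plain methyl group on this nitrogen would fare the same, and whether the defined stereocentres matter.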